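A few compounds are considered here, and "the series" means these few. Any claim that something is new, unique, unknown or untested is made for them only; others in the source may bear on it.

In an ADME assay on HepG2 cells (Homo sapiens) for cytotoxicity, with a stated time of 72 h (on this read-out lower numbers stand for an effect already at smaller amounts and higher numbers for an effect only at larger amounts of compound), three compounds with a shared core have been tested. Compound 1 (`CCc1ccc(NC(=O)Nc2cc(C)nc3ccccc23)cc1`) gives 17000 nM, and it is the only one of the three with an actual number. Compound 2 (`COc1ccc(NC(=O)Nc2cc(C)nc3ccccc23)cc1OC`) is reported only as a limit of the assay, > 25000 nM. Compound 3 (`Cc1cc(NC(=O)Nc2cccc(F)c2)c2ccccc2n1`) is likewise reported only as a limit, > 25000 nM. Apart from compound 1, the readings therefore rest on (the limit of > 25000 nM in this assay, at which 2 of the 3 values shown sit).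

Compound 4 (`Cc1cc(NC(=O)Nc2ccc(N(C)C)cc2)c2ccccc2n1`) has not yet been measured. It carries dimethylamino in place of ethyl on an aromatic carbon, para to a large group: dimethylamino in place of ethyl on an aromatic carbon. For the measured compounds named here, no two measured compounds differ in one place, so the data give no direct size for such a change. The estimate starts from compound 1 at 17000 nM. The expected step of a 1.2-fold higher number from compound 1 to compound 4 (0.09 log units; within the scatter) is estimated to stay within the usual scatter of this assay, if anything towards higher numbers. Compound 4 is expected at 21000 nM, with an estimated range from 9000 nM to 45000 nM.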

Compound 4, half-maximal effective concentration: > 25000 nM
Compound 4 was reported as a limit; the forecaster's own chance of this, stated with the estimate: 45%; middle value at least 1.1-fold (0.07 log units) away from the limit.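

For the compounds shown here, this is the first change at this position that can be read between two measured compounds, and in this assay it gives an at least 1.4-fold higher number from compound 1 to compound 4 (0.16 log units; that floor lies within the scatter). Going by these compounds alone, because compound 4 ends at a limit of the assay, this step is only a floor and not a size, and the reading is bounded by the tested range: the limit of > 25000 nM in this assay, at which 3 of the 4 values shown sit. Dimethylamino in place of ethyl on an aromatic carbon, para to a large group, therefore gives no reading of an effect at smaller amounts than in compound 1, which remains the only compound with an actual number.

From the compounds shown here alone, how far the true value of compound 4 lies past the limit stays open. Also open, going by these compounds, is what a primary amine, a carboxylic acid or a longer chain in place of ethyl would give in this assay.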